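This account rests on a few compounds, and the source may have more. Where it says the series, first, only, none or still open, it means among the compounds named here.

Measured so far:
Compound 1 `c1ccc(COC[C@H]2O[C@@H](Cc3ccccc3)[C@H](OCc3ccccc3)[C@@H](OCc3ccccc3)[C@@H]2OCc2ccccc2)cc1`: > 50000 nM (a limit, not a number)
Compound 2 `c1ccc(COC[C@H]2O[C@@H]3C[C@@H]3[C@@H](OCc3ccccc3)[C@@H]2OCc2ccccc2)cc1`: > 50000 nM (a limit, not a number)
Compound 3 `CC[C@@H]1O[C@H](COCc2ccccc2)[C@@H](OCc2ccccc2)[C@H](OCc2ccccc2)C1=O`: 4300 nM

In a functional assay on HOS cells (Homo sapiens) for antiproliferative activity, read by sulforhodamine B assay (on this read-out higher numbers stand for weaker inhibition of growth and lower numbers for stronger inhibition of growth), compound 3 is the only one of the three with a true number, 4300 nM. The other two results are limits of the assay, so they cannot be set against it as exact values.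

Compound 4 `C=CC[C@@H]1O[C@H](COCc2ccccc2)[C@@H](OCc2ccccc2)[C@H](OCc2ccccc2)C1=O` keeps the rest of compound 3 and changes one group: vinyl in place of methyl on a saturated chain carbon bound to a saturated ring carbon. Cut one bond further out, the same difference reads ethyl to allyl. Going by the values given here, no two measured compounds differ in just one place, so the data offer no direct precedent for this change. With so little altered, no step beyond the scatter is expected in this assay, and no clear direction can be called. The expected 1.2-fold lower number from compound 3 to compound 4 (0.09 log units; within the scatter) is therefore small. The estimate for compound 4 is 3500 nM, with an expected range of 1300 nM to 10000 nM.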

Compound 4, concentration for 50% growth inhibition: 7600 nM
Compound 4: the middle estimate sits 2.2-fold (0.34 log units) below what was measured; measured number inside the range.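

In this assay, going by these compounds alone, the first readable step at this position, vinyl in place of methyl on a saturated chain carbon bound to a saturated ring carbon, gives a 1.8-fold higher number from compound 3 to compound 4 (0.25 log units; within the scatter) and so cannot be told apart from repeat measurement. Read one bond further out, ethyl can therefore give way to allyl at this position with no measurable change, and compound 3 and compound 4 count as equal here. Within the data shown here, compound 1 and compound 2 are each reported only as a limit, so this single step is the only comparison available: the limit of > 50000 nM in this assay, at which 2 of the 4 values shown sit.

Open, from the compounds shown here alone, is whether an amine, a carboxylic acid or a longer chain such as hexyl on this same carbon would move the number beyond the scatter. Also open, going by these compounds, is what the carbonyl shared by compound 3 and compound 4 contributes.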